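The source may report more compounds than this note shows. Statements on the series, on what has been measured and on what is new or still open speak of the compounds shown alone.

Compound 1 `CS(=O)(=O)Nc1c(O)ccc2c1CCCC2c1c[nH]cn1` carries a free hydroxy on its aromatic ring, and in an assay on isolated protein for binding affinity to Alpha-1A adrenergic receptor (Rattus norvegicus), read by radioligand binding (a lower number here means a stronger inhibitor, a higher number a weaker inhibitor), compound 1 gives 36.3 nM. Compound 2 `COc1ccc2c(c1NS(C)(=O)=O)CCCC2c1c[nH]cn1` differs from it by methyl in place of hydrogen on an oxygen on an aromatic ring, and in this assay compound 2 gives 501 nM; that single change produced a 14-fold higher number from compound 1 to compound 2 (1.14 log units; beyond the scatter). Compound 3 `CS(=O)(=O)Nc1ccc(O)c2c1CCCC2c1c[nH]cn1` has the same atoms as compound 1 joined differently; the difference between the two cores is not broken down here. In this assay compound 3 gives 708 nM. Compound 4 `COc1ccc(NS(C)(=O)=O)c2c1C(c1c[nH]cn1)CCC2` stands to compound 3 as compound 2 stands to compound 1, the change being (methyl in place of hydrogen on an oxygen on an aromatic ring), the same change at the same kind of place. Because the earlier step was a 14-fold higher number from compound 1 to compound 2 (1.14 log units; beyond the scatter), the step from compound 3 to compound 4 is expected to be a 7.1-fold higher number from compound 3 to compound 4 (0.85 log units; beyond the scatter), though on a weaker core. Compound 4 is therefore estimated at 5000 nM, between 1500 nM and 20000 nM.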

Compound 4, inhibition constant: 1700 nM
Compound 4: middle estimate off by 2.9-fold (0.47 log units), on the high side; measured number inside the range.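

In this assay the change from hydroxy to methoxy again gave a higher number, with a 2.4-fold higher number from compound 3 to compound 4 (0.38 log units; beyond the scatter) as the new step. The direction carried over from one core to the other, but the size did not: the same change on two cores in this assay, a 14-fold higher number (1.14 log units; beyond the scatter) from compound 1 to compound 2 and a 2.4-fold higher number (0.38 log units; beyond the scatter) from compound 3 to compound 4, 5.7-fold (0.76 log units) apart, beyond the scatter of two such steps. A step measured on one core therefore gave the direction on the other but not a reliable size, and these two pairs show neither why the sizes differ nor how the change would behave on a further core.

The compounds shown leave open how a longer chain on that oxygen, such as ethoxy, would compare with methoxy on either core. They also leave open what an amine in place of the hydroxy would give.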